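Dropping the vinyloxy group: an expected small shift

A few compounds are considered here, and "the series" means these few. Any claim that something is new, unique, unknown or untested is made for them only; others in the source may bear on it.

Measured so far:
compound 1 `c1cncc(N2CCCNCCC2)c1` gives 0.891 nM in an assay on HEK293 cells for displacement of a labelled ligand from Neuronal acetylcholine receptor; alpha4/beta2 (Homo sapiens); on this read-out higher numbers stand for weaker inhibition and lower numbers for stronger inhibition
compound 2 `C=COc1cc(N2CCCNCCC2)cnc1Br` gives 0.38 nM in this assay
compound 3 `C=COc1cc(N2CCCNCC2)cnc1Br` gives 0.646 nM in this assay

Compound 2 holds the lowest of the three numbers. Its nearest neighbour is compound 3, whose number is higher by an amount that lies within the scatter, so the two cannot be told apart. Compound 1 lies furthest away, with a number higher by an amount beyond the scatter.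

The unmeasured compound 4 `Brc1ccc(N2CCCNCCC2)cn1` is reached from compound 2 by one change, hydrogen in place of vinyloxy on an aromatic carbon — hydrogen in place of vinyloxy on an aromatic carbon, with the bromo group kept. Among the compounds with values here, no pair among the measured compounds shows this change on its own, so the size of the step must be guessed from the spread of the three numbers. Compound 1, which carries neither the vinyloxy nor the bromo group, gives 0.891 nM, and compound 4 is expected to fall between that and compound 2, with a small loss at most. Compound 4 is therefore estimated at 0.6 nM, in a range from 0.25 nM to 1.5 nM. This estimate corresponds to an expected step of a 1.6-fold higher number from compound 2 to compound 4 (0.20 log units; within the scatter), close to the scatter.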

Compound 4, half-maximal inhibitory concentration: 0.447 nM
For compound 4 the middle estimate is 1.3-fold (0.13 log units) above the measured one; low and high end bracket the measured number.
By their numbers in this assay, from the lowest: compounds 2, 4, 3 and 1 (each within the scatter of the next, the first and the last beyond it).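

In this assay, hydrogen in place of vinyloxy on this aromatic carbon, ortho to a bromo group, gives a 1.2-fold higher number from compound 2 to compound 4 (0.07 log units; within the scatter), so the numbers with and without this group cannot be told apart. Bromo in place of hydrogen gives a 2.0-fold lower number from compound 1 to compound 4 (0.30 log units; within the scatter), so this single change also stays within the scatter, and neither step alone is shown to shift the number in this assay. Nothing among the available measurements offers an explanation for either step.

From the compounds shown here alone, it remains open whether a larger replacement at this aromatic carbon, such as an amine, a carboxylic acid or a longer chain, would also stay within the scatter. The compounds shown also leave open how vinyloxy behaves without the bromo group, and whether its removal from the core of compound 3 gives a similar step.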